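The Same Methyl Step Repeated on a Second Core

The source may hold more compounds than are shown below. What is called first, only, known or untested is meant among the compounds shown, and "the series" means these compounds.

In a functional assay on the whole organism for agonist activity, with Mus musculus as the target (a lower number here means that less compound is needed, a higher number that more compound is needed for the effect), compound 1 `CC(=O)N(C)C(C)C#CCn1ccnc1` gives 2 mg/kg. Compound 2 `CC(=O)N(C)C(C)C#CCn1cncc1C` reaches only a limit of this assay, > 100 mg/kg. The change between the two is methyl in place of hydrogen on an aromatic carbon, and it brings an at least 50-fold higher number from compound 1 to compound 2 (1.69 log units; beyond the scatter). Compound 3 `O=C1NCCN1CC#CCn1ccnc1` also gives only a limit in this assay, > 100 mg/kg. How the core of compound 3 differs from the core of compound 1 is not broken down here. Compound 4 `Cc1cncn1CC#CCN1CCNC1=O` carries the same change, (methyl in place of hydrogen on an aromatic carbon), made on compound 3. Compound 4 is expected to show a step that the limit leaves unreadable from compound 3 to compound 4, since compound 3 already sits at the limit of > 100 mg/kg in this assay, at which 2 of the 3 values shown sit, and the earlier step was an at least 50-fold higher number from compound 1 to compound 2 (1.69 log units; beyond the scatter). Compound 4 is therefore estimated at 300 mg/kg in this assay, within a range from 100 mg/kg to 3000 mg/kg, most likely reported again only as a limit.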

Compound 4, dose for half-maximal effect: > 100 mg/kg
Compound 4: only a limit was reported; the forecaster's own chance of this, stated with the estimate: 90%; the middle value is on the limit's open side.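

In this assay compound 4 gives > 100 mg/kg, which is a limit, as the result for compound 3 was, so no step can be read between compound 3 and compound 4. Left open is whether methyl in place of hydrogen on an aromatic carbon changes the number at all on the core of compound 3.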